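A few compounds are considered here, and "the series" means these few. Any claim that something is new, unique, unknown or untested is made for them only; others in the source may bear on it.

Compound 1 `Cc1c(Nc2nc(N)c3c(C#N)c(N4CCC[C@H]4C)n(C)c3n2)cnn1[C@H]1CCOC1`: 23 nM
Compound 2 `C[C@H]1CCCN1c1c(C#N)c2c(N)ncnc2n1C`: 5660 nM

Both numbers come from an assay on isolated protein for inhibition of Leucine-rich repeat serine/threonine-protein kinase 2 (Homo sapiens), read by TR-FRET and LanthaScreen, with stated times of 50 min and 30 min, in the presence of a further agent that is not named here; a higher number here means a weaker inhibitor, a lower number a stronger inhibitor. Compound 2 has the higher of the two numbers, and the gap to compound 1 lies well beyond the scatter, so compound 2 is the weaker inhibitor of the pair. Compound 3 `Cn1c(N)c(C#N)c2c(N)ncnc21` has not yet been measured. It differs from compound 2 in one place: amino in place of 2-methylpyrrolidin-1-yl on an aromatic carbon. Within the data shown here, no measured pair shows this kind of change, so the direction rests on expectation alone: a modest rise in the number, meaning weaker inhibition, is expected. Compound 3 is expected to give 15000 nM, in the range 4000 nM to 60000 nM, a step of a 2.7-fold higher number from compound 2 to compound 3 (0.42 log units; beyond the scatter).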

Compound 3, half-maximal inhibitory concentration: 14400 nM
Estimate against measurement, compound 3: 1.0-fold (0.02 log units) above, and the stated range covers the measured number.
By their numbers in this assay, from the lowest: compound 1; then compound 2; then compound 3.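

Putting amino in place of 2-methylpyrrolidin-1-yl on this aromatic carbon gives a 2.5-fold higher number from compound 2 to compound 3 (0.41 log units; beyond the scatter), a modest loss of inhibition that lies beyond the scatter. Inhibition remains measurable without the ring, so on this small core the 2-methylpyrrolidin-1-yl group accounts for only a modest part of it. Nothing measured here gives a reason for the step.

From the compounds shown here alone, whether a dimethylamino or morpholine group on this carbon would fall nearer compound 2 or compound 3 remains open. So does whether the same change would cost as little on compound 1.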